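A few compounds are considered here, and "the series" means these few. Any claim that something is new, unique, unknown or untested is made for them only; others in the source may bear on it.

Working notes on the series. In a functional assay on CCRF-CEM cells for antagonist activity at C-X-C chemokine receptor type 4 (Homo sapiens), read by calcium flux, with stated times of 25 min and 90 s (on this read-out lower numbers stand for stronger inhibition and higher numbers for weaker inhibition), compound 1 `c1ccc2c(c1)CN[C@H](CN(CCCN1CCNCC1)[C@H]1CCCc3cccnc31)C2` gives 1150 nM, compound 2 `c1cnc2c(c1)CN[C@H](CN(CCCN1CCNCC1)[C@H]1CCCc3cccnc31)C2` gives 2640 nM, and compound 3 `c1cnc2c(c1)CN[C@@H](CN(CCCN1CCNCC1)[C@H]1CCCc3cccnc31)C2` gives 171 nM. Compound 3 stands lowest of the three numbers, with both of its steps beyond the scatter: a 6.7-fold lower number from compound 1 to compound 3 (0.83 log units; beyond the scatter) and a 15-fold lower number from compound 2 to compound 3 (1.19 log units; beyond the scatter). The step of a 2.3-fold higher number from compound 1 to compound 2 (0.36 log units; beyond the scatter) went the other way. The large gap between compound 2 and compound 3 rests on (the fact that compounds 2 and 3 differ only in the configuration as drawn), so the group on the saturated chain carbon bound to the amine nitrogen, and its configuration, carry much of the spread seen so far.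

Compound 4 `c1cnc2c(c1)CCC[C@@H]2N(CCCN1CCNCC1)Cc1nc2ccccc2[nH]1` changes exactly that place: a group of 9 heavy atoms (7 carbon, 2 nitrogen; one five-membered aromatic ring with 2 hetero atoms, one six-membered aromatic ring of carbon only) in place of a group of 10 heavy atoms (8 carbon, 2 nitrogen; one six-membered non-aromatic ring with 1 hetero atom, one six-membered aromatic ring with 1 hetero atom), on a saturated chain carbon bound to an amine nitrogen. The defined stereocentre of the leaving group is lost with it. The measured steps at this position span the modest change from compound 1 to compound 2 and from compound 1 to compound 3 up to the large one from compound 2 to compound 3, so a step of that order in this assay is expected, more likely upward from compound 3 than downward given that compound 3 is the lowest number seen. For compound 4 the expected step is a 3.5-fold higher number from compound 3 to compound 4 (0.55 log units; beyond the scatter), with an estimate of 600 nM and a range from 120 nM to 3000 nM.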

Compound 4, half-maximal inhibitory concentration: 45 nM
The estimate for compound 4 lay 13-fold (1.12 log units) above the measured number, outside the stated range (below it).
By their numbers in this assay, from the lowest: compound 4; then compound 3; then compound 1; then compound 2.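

In this assay, 1H-benzimidazol-2-yl on a saturated chain carbon bound to an amine nitrogen gives a further drop below the best of the earlier groups (a 3.8-fold lower number from compound 3 to compound 4 (0.58 log units; beyond the scatter)). Among the compounds shown here, a low number at this place therefore needs neither the six-membered non-aromatic ring nor the defined stereocentre that configuration had made decisive among the earlier compounds. The gaps to the other two are larger (a 26-fold lower number from compound 1 to compound 4 (1.41 log units; beyond the scatter); a 59-fold lower number from compound 2 to compound 4 (1.77 log units; beyond the scatter)), and no measurement shown bears on why this change lowers the number.

Open, going by these compounds, is how much of the entering group is needed: whether imidazol-2-yl, lacking the six-membered aromatic ring of carbon only, would keep the number. Also open, on these data alone, is whether a methyl group on the ring nitrogen in place of its hydrogen would keep it.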